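From Methoxy to Methyl in Compound 1

The compounds below may be only part of what the source reports. "The series", "measured", "known", "first", "only" and "open" are said of these compounds alone.

Among the compounds with values here, in a functional assay on HepG2 cells (Homo sapiens) for inhibition, read by CCK-8 assay, with a stated time of 48 h (a lower number here means a stronger inhibitor, a higher number a weaker inhibitor), compound 1 (`COc1ccc(C2=NN(C3=NC(c4ccccc4)CS3)C(c3cccc4ccccc34)C2)cc1`) gives 8740 nM and sits at the low end of the three numbers measured so far. Compound 2 (`COc1ccc(C2=NN(C3=NC(c4ccccc4)CS3)C(c3ccc4ccccc4c3)C2)cc1`) gives 12600 nM and is level with compound 1 within the usual scatter of repeated measurements. Compound 3 (`O=C1CSC(N2N=C(c3ccc(Br)cc3)CC2c2ccc3ccccc3c2)=N1`) gives 18200 nM and lies just beyond that scatter from compound 1.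

Compound 4 (`Cc1ccc(C2=NN(C3=NC(c4ccccc4)CS3)C(c3cccc4ccccc34)C2)cc1`) keeps the core of compound 1 and changes one group, 4-methoxyphenyl to 4-methylphenyl (methyl in place of methoxy on an aromatic carbon), which puts methyl in place of methoxy on an aromatic carbon. Within the data shown here, only one measured step changes a single place (a 1.4-fold higher number from compound 1 to compound 2 (0.16 log units; within the scatter)), with naphthalen-2-yl in place of naphthalen-1-yl on a saturated ring carbon. That step stays within the scatter, but it concerns a different group and says nothing direct about methoxy. Compound 3 differs from compound 1 in more than one place, so it isolates no single change.

Among the measured compounds shown here, no measured pair compares methoxy with methyl. The starting point in this assay is compound 1, which gives 8740 nM. No shift beyond the scatter is therefore expected from that number, and neither direction can be favoured. The expected step (a 1.1-fold higher number from compound 1 to compound 4 (0.04 log units; within the scatter)) is small. Compound 4 is estimated at 9500 nM (range 4500 nM to 20000 nM).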

Compound 4, half-maximal inhibitory concentration: 10400 nM
Beside the measured number, compound 4's estimate is 1.1-fold (0.04 log units) below it; low and high end bracket the measured number.
By their numbers in this assay, from the lowest: compounds 1, 4, 2 and 3 (each within the scatter of the next, the first and the last beyond it).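

In this assay, within the data shown here, this pair is the first to test the group on an aromatic carbon para to a large group: 4-methylphenyl in place of 4-methoxyphenyl gives a 1.2-fold higher number from compound 1 to compound 4 (0.08 log units; within the scatter) and leaves the two compounds level. The change takes away one heavy atom, the oxygen, and with it the only hydrogen-bond acceptor in the leaving group, yet in this single pair the number does not move beyond the usual scatter. The data offer no measured explanation for why these two groups read alike.

From the compounds shown here alone, what remains open is whether this position tolerates groups that differ more sharply from methoxy and methyl, such as an amine, a carboxylic acid or a longer chain like butoxy, any of which could show whether the number can move here at all. Going by these compounds, it is also open whether the same swap would leave the number level on the naphthalen-2-yl partner, compound 2, since this pair tests it only alongside the naphthalen-1-yl group.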